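Replacing the Amine Side Chain with an Amino Acid

The compounds below may be only part of what the source reports. "The series", "measured", "known", "first", "only" and "open" are said of these compounds alone.

Compound 1 `CCN(CC)CCNC(=O)c1ccc(C(CC)(CC)c2ccc(OCC(=O)C(C)(C)C)c(C)c2)n1CC` gives 690 nM in a functional assay on MCF7 cells (Homo sapiens), read by MTT assay, with a stated time of 48 h (a higher number here means a weaker inhibitor, a lower number a stronger inhibitor), level with compound 2 `CCN(CC)CCNC(=O)c1ccc(C(CC)(CC)c2ccc(OCC(O)C(C)(C)C)c(C)c2)n1CC`, which gives 690 nM; the step of no change at the digits printed from compound 1 to compound 2 (within the scatter) stays within the scatter. Compound 3 `CCn1c(C(=O)NCC(OC)OC)ccc1C(CC)(CC)c1ccc(OCC(O)C(C)(C)C)c(C)c1` gives only a limit of the assay, > 50000 nM. For the measured compounds named here, the step of an at least 72-fold higher number from compound 2 to compound 3 (1.86 log units; beyond the scatter) is the one measured change that alters the group carried on the amide-type nitrogen, and it was large. Compound 4 `CC[C@@H](C)[C@H](NC(=O)c1ccc(C(CC)(CC)c2ccc(OCC(=O)C(C)(C)C)c(C)c2)n1CC)C(=O)O` is not yet measured; it differs from compound 1 as follows: 1-carboxy-2-methylbutyl in place of 2-(diethylamino)ethyl on an amide-type nitrogen. As in the change from compound 2 to compound 3, the diethylamino end of the side chain is taken away, here with 1-carboxy-2-methylbutyl entering in place of 2-(diethylamino)ethyl. Going by the values given here, only that single measured step bears on the change, and it was large, so a large rise in the number is expected for compound 4, a 58-fold higher number from compound 1 to compound 4 (1.76 log units; beyond the scatter), possibly reaching the limit (the limit of > 50000 nM in this assay, at which 1 of the 3 values shown sits). Compound 4 is therefore estimated at 40000 nM, with a range from 5000 nM to 200000 nM.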

Compound 4, half-maximal inhibitory concentration: 160 nM
For compound 4 the middle estimate is 250-fold (2.40 log units) above the measured one; the measured number lies below the stated range.
By their numbers in this assay, from the lowest: compound 4; then compounds 1 and 2 (each within the scatter of the next). At a limit, above all of these: compound 3.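

In this assay, the amide-type nitrogen tolerates the loss of 2-(diethylamino)ethyl when 1-carboxy-2-methylbutyl enters, giving a 4.3-fold lower number from compound 1 to compound 4 (0.63 log units; beyond the scatter) rather than a rise. Removing the diethylamino end is therefore not enough on its own to produce a change like an at least 72-fold higher number from compound 2 to compound 3 (1.86 log units; beyond the scatter), and the group that enters in its place counts for much in this series. Nothing measured here accounts for the opposite directions of these two steps.

From the compounds shown here alone, it remains open whether the lower number follows the carboxylic acid or the branched chain: a methyl ester, or an amino acid with a shorter chain such as glycine, would separate the two. Also open, going by these compounds, is whether the 1-hydroxy-2,2-dimethylpropyl group, in place of the (tert-butyl)carbonyl group, would leave the number unchanged alongside the 1-carboxy-2-methylbutyl side chain.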